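Working notes: methyl to ethyl on compound 1

This account rests on a few compounds, and the source may have more. Where it says the series, first, only, none or still open, it means among the compounds named here.

Measured so far in a functional assay on HT-29 cells (Homo sapiens) for antiproliferative activity, read by sulforhodamine B assay, with a stated time of 48 h; a higher number here means a weaker inhibitor, a lower number a stronger inhibitor
compound 1 (`CN1CCN(c2ccc(S(=O)(=O)Oc3cccc(I)c3)cc2)C1=O`) 590 nM
compound 2 (`CN1CCN(c2ccc(S(=O)(=O)Oc3cccc([N+](=O)[O-])c3)cc2)C1=O`) 26000 nM
compound 3 (`CN1CCN(c2ccc(S(=O)(=O)Oc3ccc(Cl)cc3)cc2)C1=O`) 12000 nM

Compound 1 has the lowest number of the three. a 20-fold higher number from compound 1 to compound 3 (1.31 log units; beyond the scatter) and a 44-fold higher number from compound 1 to compound 2 (1.64 log units; beyond the scatter) stand as large steps beyond the scatter. Compound 4 (`CCN1CCN(c2ccc(S(=O)(=O)Oc3cccc(I)c3)cc2)C1=O`) changes methyl to ethyl, 3-methyl-2-oxoimidazolidin-1-yl to 3-ethyl-2-oxoimidazolidin-1-yl (methyl in place of hydrogen on a saturated chain carbon bound to an amide-type nitrogen in a ring). For the measured compounds named here, no measured step tests this place. Both measured steps replace the 3-iodophenyl group or its iodo, and compound 4 keeps that group. Compound 4 is expected to stay near compound 1 at 590 nM with no step beyond the scatter in this assay at this change. The expected step is small (a 1.2-fold lower number from compound 1 to compound 4 (0.07 log units; within the scatter)). The estimate for compound 4 is 500 nM (expected range 150 nM to 1700 nM).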

Compound 4, half-maximal inhibitory concentration: 3100 nM
Compound 4: the middle estimate sits 6.2-fold (0.79 log units) below what was measured, outside the stated range (above it).
By their numbers in this assay, from the lowest: compound 1; then compound 4; then compound 3; then compound 2.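

The 3-methyl-2-oxoimidazolidin-1-yl end of the series is not neutral in this assay: going to 3-ethyl-2-oxoimidazolidin-1-yl gives a 5.3-fold higher number from compound 1 to compound 4 (0.72 log units; beyond the scatter). The earlier steps shown here changed only the iodophenyl side, whereas this one shows that a single added methyl on a saturated chain carbon bound to an amide-type nitrogen in a ring also moves the number beyond the scatter. Nothing available here accounts for this step. The compounds shown leave open whether a longer chain, such as propyl, or a hydroxyethyl group at this place would raise the number further. They also leave open whether methyl to ethyl has a similar effect on compound 2 or compound 3.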